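The source may hold more compounds than are shown below. What is called first, only, known or untested is meant among the compounds shown, and "the series" means these compounds.

Measured so far in a physicochemical assay for lipophilicity, using the shake flask method, in phosphate buffer, measured as octanol-water partition, with a stated time of 1 h, at pH 7.4; on this read-out lower numbers stand for lower lipophilicity and higher numbers for higher lipophilicity:
- compound 1, `CCNC(=O)Nc1cc(-c2nc(C(F)(F)F)cs2)c(-c2cncc(-c3c(C)noc3C)c2)cn1`: 3.5
- compound 2, `CCNC(=O)Nc1cc(-c2ccncc2)c(-c2cncc(C(=O)O)c2)cn1`: -0.82
- compound 3, `CCNC(=O)Nc1cc(-c2cccnc2)c(-c2cncc(C(=O)O)c2)cn1`: -1.5

Compound 1 stands highest of the three numbers in this assay, far above compound 2 and further still above compound 3, both of which carry a carboxylic acid where compound 1 carries its trifluoromethyl-substituted thiazole. Among the measured compounds shown here, the one measured step, a number 0.68 log units lower from compound 2 to compound 3 (beyond the scatter), concerns only the exchange of one pyridyl isomer for another and is modest.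

Compound 4, `CCNC(=O)Nc1cc(-c2nc(C(F)(F)F)cs2)c(-c2cncc(C(N)=O)c2)cn1`, keeps the core of compound 1 and its thiazole but differs in one place: carbamoyl in place of 3,5-dimethyl-1,2-oxazol-4-yl on an aromatic carbon. For the measured compounds named here, no measured step covers this change. The step from compound 2 to compound 3 does not bear on it, and the acid-bearing compounds 2 and 3 show only that a polar, ionisable group at that position sits far below compound 1; a carbamoyl is neither an acid nor a dimethyl-oxazole, so those values set no direct anchor. A step well beyond the scatter, downward, is nevertheless expected, since a small group with a hydrogen-bond donor enters and a larger carbon-rich ring leaves.

For compound 4 the expected result in this assay is 1.3, with a range of 0.6 to 2, meaning an estimated step of a number 2.20 log units lower from compound 1 to compound 4 (beyond the scatter).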

Compound 4, distribution coefficient: 2
The estimate for compound 4 lay 0.70 log units below the measured number; the measured number falls inside the stated range.
By their numbers in this assay, from the lowest: compound 3; then compound 2; then compound 4; then compound 1.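

Notes on the position two atoms from the ring nitrogen: in this assay, replacing 3,5-dimethyl-1,2-oxazol-4-yl with carbamoyl gives a number 1.50 log units lower from compound 1 to compound 4 (beyond the scatter), the first measured size for a change at this position with the rest of compound 1 held fixed. This one change removes a ring, reduces the heavy-atom count and introduces a hydrogen-bond donor, yet compound 4 still reads 2 on this scale, so the position can move the read-out substantially without taking it below zero in this pair. No measurement shown here accounts for the size of this step.

A single pair cannot separate the loss of the ring, the smaller size of the group and the arrival of the hydrogen-bond donor; a nitrile or a methyl carbamoyl at the same aromatic carbon would help to pull these apart. Also open, from the compounds shown here alone, is how far the step carries over to other groups on the shared core, for example whether a carbamoyl would give a similar change with pyridin-3-yl or pyridin-4-yl in place of the trifluoromethyl-substituted thiazole.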